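A few compounds are considered here, and "the series" means these few. Any claim that something is new, unique, unknown or untested is made for them only; others in the source may bear on it.

Among the measured compounds shown here, compound 2 (`N[C@H]1CC[C@H](Nc2c(C(=O)NCc3ccc(F)cc3)nc(Br)c3cccnc23)CC1`) gives 7000 nM in a functional assay on HCT-116 cells (Homo sapiens) for cytotoxicity, read by MTT assay, with a stated time of 72 h (a lower number here means a stronger inhibitor, a higher number a weaker inhibitor), the only actual number so far. Compound 1 (`O=C(NCc1ccc(F)cc1)c1nc(Br)c2cccnc2c1NCc1ccc(F)cc1`) reads > 20000 nM, which is a limit of the assay and not a number. For the measured compounds named here, the single measured step is an at least 2.8-fold lower number from compound 1 to compound 2 (0.45 log units; beyond the scatter), with 4-aminocyclohexyl in place of 4-fluorobenzyl on a nitrogen on an aromatic ring. Going by these compounds, since one end of it is the limit of > 20000 nM in this assay, at which 1 of the 2 values shown sits, its true size remains open.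

Compound 3 (`C[C@H](Nc1c(C(=O)NCc2ccc(F)cc2)nc(Br)c2cccnc12)c1ccccc1`) changes the same place: 1-phenylethyl in place of 4-aminocyclohexyl on a nitrogen on an aromatic ring. Here 4-aminocyclohexyl leaves again, and 1-phenylethyl enters with its six-membered aromatic ring of carbon only. Going by the values given here, the one measured step therefore bears on this change when read in reverse, although 1-phenylethyl is not the group that 4-aminocyclohexyl replaced in compound 2. On the strength of an at least 2.8-fold lower number from compound 1 to compound 2 (0.45 log units; beyond the scatter), a move to a higher number in this assay is expected, of similar size, and a reading at the limit would be no surprise. The expected step is a 2.7-fold higher number from compound 2 to compound 3 (0.43 log units; beyond the scatter). Compound 3 is estimated at 19000 nM, with an expected range of 8000 nM to 45000 nM.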

Compound 3, half-maximal inhibitory concentration: > 20000 nM
Compound 3: only a limit was reported; the forecaster's own chance of this, stated with the estimate: 50%; middle value at least 1.0-fold (0.02 log units) away from the limit.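

At this place, on a nitrogen on an aromatic ring, the departure from 4-aminocyclohexyl now has a second reading: in this assay the series shows an at least 2.8-fold higher number from compound 2 to compound 3 (0.45 log units; beyond the scatter). The lower number of compound 2 therefore holds against two different groups, since 4-fluorobenzyl in compound 1 and 1-phenylethyl in compound 3 both give only a limit of the assay and not a number, while 4-aminocyclohexyl alone gives a number; none of the three compounds goes against this, though three compounds are a narrow base. The true size of this step stays open, and the step between compound 1 and compound 3 cannot be read: the limit of > 20000 nM in this assay, at which 2 of the 3 values shown sit.

The compounds shown do not separate the amine of 4-aminocyclohexyl from its six-membered non-aromatic ring, so a plain cyclohexyl group and a 1-phenylethyl group carrying an amine on its ring would each bear on which part goes with the lower number. Also open, going by these compounds, is whether a simple aminoalkyl chain on this nitrogen would give a number, and how it would stand against compound 2.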